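Sulfonamide side chain versus a small silicon group

This account rests on a few compounds, and the source may have more. Where it says the series, first, only, none or still open, it means among the compounds named here.

Measured in a functional assay on HCT-116 cells (Homo sapiens) for antiproliferative activity, read by MTT assay, with a stated time of 72 h; on this read-out higher numbers stand for weaker inhibition and lower numbers for stronger inhibition:
compound 1 `CCCCCCCCCCc1cn(C[C@H](O)[C@H]2OC(=O)C(OCc3ccccc3)=C2OCc2ccccc2)nn1` gives 28800 nM
compound 2 `CC(C)(C)c1cn(C[C@H](O)[C@H]2OC(=O)C(OCc3ccccc3)=C2OCc2ccccc2)nn1` gives 28300 nM
compound 3 `O=C1O[C@H]([C@@H](O)Cn2cc(CNS(=O)(=O)c3ccc(Cl)cc3)nn2)C(OCc2ccccc2)=C1OCc1ccccc1` gives 8380 nM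

Of the three, compound 3 has the lowest number at 8380 nM, and its steps to both others lie beyond the scatter. The next change leads to compound 4 `C[Si](C)(C)c1cn(C[C@H](O)[C@H]2OC(=O)C(OCc3ccccc3)=C2OCc2ccccc2)nn1` and is a group of 4 heavy atoms (3 carbon, 1 silicon; no ring) in place of a group of 12 heavy atoms (7 carbon, 1 nitrogen, 2 oxygen, 1 sulfur, 1 chlorine; one six-membered aromatic ring of carbon only), on an aromatic carbon. It sits on an aromatic carbon of a five-membered aromatic ring.

For the measured compounds named here, three measured steps bear on this. The closest is a 3.4-fold lower number from compound 2 to compound 3 (0.53 log units; beyond the scatter), which introduces the same leaving group in place of tert-butyl on that carbon. The step of a 3.4-fold lower number from compound 1 to compound 3 (0.54 log units; beyond the scatter) is of similar size. The step of a 1.0-fold lower number from compound 1 to compound 2 (0.01 log units; within the scatter) shows that exchanging decyl for tert-butyl gave no change in this assay. Both of those compounds lack the (((4-chlorophenyl)sulfonyl)amino)methyl group and sit together at the high end. Going by the values given here, no measured compound carries silicon, so the reading rests on the entering group having no ring, like decyl and tert-butyl. Removing the sulfonyl-bearing group is therefore expected to reverse the modest gain. The expected change is a 3.1-fold higher number from compound 3 to compound 4 (0.49 log units; beyond the scatter), towards a higher number and weaker inhibition. Compound 4 is estimated at 26000 nM, with an expected range of 11000 nM to 60000 nM.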

Compound 4, half-maximal inhibitory concentration: 31800 nM
Beside the measured number, compound 4's estimate is 1.2-fold (0.09 log units) below it; measured number inside the range.
By their numbers in this assay, from the lowest: compound 3; then compounds 2, 1 and 4 (each within the scatter of the next).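

Silicon on this aromatic carbon of the five-membered aromatic ring does not separate the new compound from the carbon-only groups in this assay: replacing tert-butyl gives a 1.1-fold higher number from compound 2 to compound 4 (0.05 log units; within the scatter), and replacing decyl gives a 1.1-fold higher number from compound 1 to compound 4 (0.04 log units; within the scatter), so these ring-free groups cannot be told apart here despite their different heavy-atom counts. Against the sulfonamide side chain, the same silicon group gives a 3.8-fold higher number from compound 3 to compound 4 (0.58 log units; beyond the scatter), which leaves compound 3, the only one of the four carrying (((4-chlorophenyl)sulfonyl)amino)methyl, apart from compounds 1, 2 and 4, with no compound here going against that split. No measurement at hand accounts for this split.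

The compounds shown do not separate the contributions of the 4-chlorophenyl ring, the sulfonyl and the amide hydrogen, so it remains open whether a methanesulfonylaminomethyl group or an unsubstituted phenylsulfonylaminomethyl group would stay with compound 3 or join the other three. Also open, as far as these compounds go, is how a simple aminomethyl group or a carboxylic acid on the same carbon would read in this assay.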